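The compounds below may be only part of what the source reports. "The series", "measured", "known", "first", "only" and "open" are said of these compounds alone.

Measured so far:
- compound 1 `CC(=O)c1ccc2[nH]c(-c3ccc(Cl)cc3)nc2c1` — in an ADME assay on MDBK cells (Bos taurus) for cytotoxicity, read by MTT assay, with a stated time of 96 h (a higher number here means that more compound is tolerated, a lower number that less compound is tolerated), compound 1 gives > 100000 nM, a limit of the assay and not a number.
- compound 2 `C/C(=N\NC(N)=S)c1ccc2[nH]c(-c3ccc(Cl)cc3)nc2c1` — in this assay compound 2 gives > 100000 nM, also a limit of the assay.

Compound 2 thus stands at the limit of this assay, where both values shown sit (the limit of > 100000 nM in this assay, at which 2 of the 2 values shown sit). Among the measured compounds shown here, the one measured step, a step that the two limits leave unreadable from compound 1 to compound 2, runs from one limit to another and its size cannot be read; it says only that both compounds were tolerated up to the top of the tested range.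

Compound 3 `C/C(=N\NC(N)=S)c1ccc2c(c1)nc(-c1ccc(Cl)cc1)n2C1CCCCC1` differs from compound 2 by cyclohexyl in place of hydrogen on an aromatic nitrogen. For the measured compounds named here, no measured step touches that position of the shared core, and the only step available is unreadable, so nothing in the numbers points to a direction for this assay. The working assumption is that compound 3 will again reach the limit, with a fair chance that a number below it appears.

Compound 3 is therefore expected to give 100000 nM, estimated between 30000 nM and 300000 nM. The expected step is a number no higher from compound 2 to compound 3 (the limit leaves the size open), no change beyond the scatter.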

Compound 3, half-maximal cytotoxic concentration: > 100000 nM
Compound 3: only a limit was reported (the forecaster's own chance of this, stated with the estimate: 55%); the middle value lies on the limit itself.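

In this assay compound 3 gives > 100000 nM, a limit of the assay and not a number, and the step from compound 2, with cyclohexyl in place of hydrogen on an aromatic nitrogen, cannot be read. The compounds shown leave open where the true tolerated concentrations lie and whether cyclohexyl changes them at all.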